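The source may report more compounds than this note shows. Statements on the series, on what has been measured and on what is new or still open speak of the compounds shown alone.

Compound 1 `COC[C@]1(C(=O)N2CC[C@](c3ccc(C(F)(C(F)(F)F)C(F)(F)F)cc3)(S(=O)(=O)c3ccc(F)cc3)C2)CC[C@H](C(=O)O)CC1` is one of three close relatives that share a core and differ only in the group attached to the carbonyl carbon. In an ADME assay on microsomes from liver (Homo sapiens) for metabolic stability, with a stated time of 10 min (a higher number here means that more of the compound is left, a lower number that less of the compound is left), compound 1 gives 100%, and it stands level with its two neighbours: compound 2 `O=C(O)C12CCC(C(=O)N3CC[C@](c4ccc(C(F)(C(F)(F)F)C(F)(F)F)cc4)(S(=O)(=O)c4ccc(F)cc4)C3)(CC1)CC2` gives 100% and compound 3 `O=C([C@H]1CC[C@H](c2nnn[nH]2)CC1)N1CC[C@](c2ccc(C(F)(C(F)(F)F)C(F)(F)F)cc2)(S(=O)(=O)c2ccc(F)cc2)C1` gives 100%. The steps among them are flat: no change at the digits printed from compound 1 to compound 2 (within the scatter), no change at the digits printed from compound 1 to compound 3 (within the scatter) and no change at the digits printed from compound 2 to compound 3 (within the scatter).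

Compound 4 `O=C(N1CC[C@](c2ccc(C(F)(C(F)(F)F)C(F)(F)F)cc2)(S(=O)(=O)c2ccc(F)cc2)C1)C1(F)CCS(=O)(=O)CC1` has not yet been measured in this assay. Its change from compound 1 is 4-fluoro-1,1-dioxothian-4-yl in place of 4-carboxy-1-(methoxymethyl)cyclohexyl on a carbonyl carbon. The measured steps all swap one group on that same carbonyl carbon without moving the read-out, but none of them brings in a 4-fluoro-1,1-dioxothian-4-yl group, so they bear on this step only loosely. On that basis the expected step is a number 10 percentage points lower from compound 1 to compound 4 (within the scatter), that is, at most a small fall that may well stay within the scatter. The estimate for compound 4 in this assay is therefore 90%, with a range from 60% to 100%.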

Compound 4, percent of the compound remaining: 100%
Estimate against measurement, compound 4: 10 percentage points below, within the range that was stated.
By their numbers in this assay, from the lowest: compounds 1, 2, 3 and 4 (each within the scatter of the next).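

In this assay, a group of a different kind can sit on this carbonyl carbon with the read-out staying flat: 4-fluoro-1,1-dioxothian-4-yl, with a hetero atom in its ring and no hydrogen-bond donor, gives (no change at the digits printed from compound 1 to compound 4 (within the scatter)). The same holds against the other two compounds (no change at the digits printed from compound 3 to compound 4 (within the scatter)) and (no change at the digits printed from compound 2 to compound 4 (within the scatter)), so among these compounds neither the carboxylic acid of compounds 1 and 2 nor the tetrazole of compound 3 is needed for the read-out to stay level. Nothing measured here explains this flat result.

As far as these compounds go, all four compounds print the same value, so they cannot be ranked, and the share of the fluorine remains unknown without the matching 1,1-dioxothian-4-yl group. From the compounds shown here alone, whether an amine or a longer chain on this carbonyl carbon would also leave the read-out level stays open.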